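The compounds below may be only part of what the source reports. "The series", "measured", "known", "first", "only" and "open" are said of these compounds alone.

Measured so far:
compound 1, `O=C(COc1cccc2ccccc12)N/N=C/c1ccccc1Br`: >= 20 ug/mL
compound 2, `COc1ccc(/C=N/NC(=O)COc2cccc3ccccc23)cc1O`: 100 ug/mL
compound 3, `O=C(COc1cccc2ccccc12)N/N=C/c1ccccc1O`: 20 ug/mL

In an ADME assay on HEL cells (Homo sapiens) for cytotoxicity (a higher number here means that more compound is tolerated, a lower number that less compound is tolerated), compound 1 gives >= 20 ug/mL; this is a limit of the assay, not a number. Compound 2 gives 100 ug/mL and compound 3 gives 20 ug/mL, so compound 3 holds the lowest of the two numbers, with compound 2 the nearer one at a gap beyond the scatter. For the measured compounds named here, the only measured step touching compound 3 is a number no higher from compound 1 to compound 3 (the limit leaves the size open), whose size stays open because of the limit of >= 20 ug/mL in this assay, at which 1 of the 3 values shown sits; it cannot be read as a size.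

Compound 4, `COc1ccc(/C=N/NC(=O)COc2cccc3ccccc23)cc1`, is not yet measured. It differs from compound 3 by 4-methoxyphenyl in place of 2-hydroxyphenyl on a carbon with a double bond to nitrogen. Going by the values given here, no measured step covers this change directly. Compound 2 carries the 4-methoxyphenyl together with a hydroxy and gives the higher number, which is the only pointer available. The expected step in this assay is therefore a 2.5-fold higher number from compound 3 to compound 4 (0.40 log units; beyond the scatter), upward, though without a directly matching step the range is kept wide. Compound 4 is estimated at 50 ug/mL, within 20 ug/mL to 100 ug/mL.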

Compound 4, minimum cytotoxic concentration: 20 ug/mL
Compound 4: middle estimate off by 2.5-fold (0.40 log units), on the high side; the measured number falls inside the stated range.
By their numbers in this assay, from the lowest: compounds 3 and 4 (each within the scatter of the next); then compound 2.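

In this assay, 4-methoxyphenyl in place of 2-hydroxyphenyl on a carbon with a double bond to nitrogen gives no change at the digits printed from compound 3 to compound 4 (within the scatter), so this position shows no readable difference between the two groups, even though the hydrogen-bond donor count goes from 1 to 0. Hydrogen in place of hydroxy on an aromatic carbon gives a 5.0-fold lower number from compound 2 to compound 4 (0.70 log units; beyond the scatter), the first readable step in the series beyond the scatter; hydroxy goes with the higher number only in compound 2, and compound 3 goes against any general link between hydroxy and a higher number. 4-methoxyphenyl in place of 2-bromophenyl on a carbon with a double bond to nitrogen gives a number no higher from compound 1 to compound 4 (the limit leaves the size open). This step cannot be read, as the value of compound 1 is a limit of the assay and not a number: the limit of >= 20 ug/mL in this assay, at which 1 of the 4 values shown sits.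

The compounds shown leave open whether the higher number of compound 2 belongs to hydroxy as such or would also appear with an amine or a carboxylic acid on that aromatic carbon. They also leave open whether a longer chain in place of the methoxy of compound 4 would shift the number in this assay.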